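This account rests on a few compounds, and the source may have more. Where it says the series, first, only, none or still open, it means among the compounds named here.

Measured so far:
Compound 1 `CC(=O)OC[C@H]1O[C@@H](N2C(=O)/C(=C3/C(=O)Nc4ccc(I)cc43)c3ccccc32)[C@H](OC(C)=O)[C@@H](OC(C)=O)[C@@H]1OC(C)=O`: 11300 nM
Compound 2 `CC(=O)OC[C@H]1O[C@@H](N2C(=O)/C(=C3/C(=O)Nc4ncccc43)c3ccccc32)[C@H](OC(C)=O)[C@@H](OC(C)=O)[C@@H]1OC(C)=O`: 27400 nM

In an ADME assay on L6 cells (Rattus norvegicus) for cytotoxicity, read by resazurin assay, with a stated time of 72 h (on this read-out lower numbers stand for stronger inhibition and higher numbers for weaker inhibition), compound 2 gives 27400 nM, the higher of the two numbers, while compound 1 gives 11300 nM. That gap lies beyond the usual scatter, so compound 2 is the weaker inhibitor of these cells so far.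

The next compound, compound 3 `CC(=O)OC[C@H]1O[C@@H](N2C(=O)/C(=C3/C(=O)Nc4ncc(Br)cc43)c3ccccc32)[C@H](OC(C)=O)[C@@H](OC(C)=O)[C@@H]1OC(C)=O`, changes compound 2 in one place: bromo in place of hydrogen on an aromatic carbon. A bromo replaces hydrogen on an aromatic carbon of a six-membered aromatic ring with 1 nitrogen, two atoms from the ring nitrogen.

No single-place change has been measured yet, so the evidence is thin. Within the data shown here, the only guide is that compound 1, at 11300 nM, sits lower, so a modest move towards lower numbers seems likely. The expected change is a 2.0-fold lower number from compound 2 to compound 3 (0.29 log units; within the scatter), only somewhat beyond the scatter. The estimate for compound 3 is 14000 nM, within an expected range of 6000 nM to 35000 nM.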

Compound 3, half-maximal inhibitory concentration: 26100 nM
Compound 3: middle estimate off by 1.9-fold (0.27 log units), on the low side; the measured number falls inside the stated range.
By their numbers in this assay, from the lowest: compound 1; then compounds 3 and 2 (each within the scatter of the next).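

In this assay a bromo in place of hydrogen on this aromatic carbon, two atoms from the ring nitrogen, gives a 1.0-fold lower number from compound 2 to compound 3 (0.02 log units; within the scatter) and so leaves the read-out effectively unchanged. Among these compounds, this is the first step here that alters a single place, and it shows that this position can carry a bromine atom with no shift in cell toxicity beyond the scatter. Nothing available explains why the number holds steady.

Going by these compounds, it remains open whether other groups at this carbon, such as an amine, a carboxylic acid or a methoxy group, would move the number in either direction. On these data alone, it is also open whether a bromo would behave the same way on the other aromatic carbons of this ring.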